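Ring Amide in Place of Ethylamide at the Carbonyl

This account rests on a few compounds, and the source may have more. Where it says the series, first, only, none or still open, it means among the compounds named here.

Of the compounds shown here, three built on a shared core have been measured in an assay on the whole organism (plasma, strain Sprague-Dawley) for inhibition of Dipeptidyl peptidase 4 (Rattus norvegicus), with a stated time of 6 h, at a dose of 1 mg/kg by the oral route; on this read-out lower numbers stand for less inhibition and higher numbers for more inhibition at the one dose given (going by the name of the read-out). Compound 1 `C[C@@H]1N[C@H](C(=O)N2CCC[C@H]2C#N)C[C@@H]1C(=O)N1CCSCC1` gives 92%, compound 2 `N#C[C@@H]1CCCN1C(=O)[C@@H]1C[C@H](C(=O)N2CCCCC2)CN1` gives 84%, and compound 3 `CCNC(=O)[C@@H]1CN[C@H](C(=O)N2CCC[C@H]2C#N)C1` gives 60%, which is the lowest of the three numbers, both gaps lying beyond the scatter.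

Within the data shown here, the one single-point step measured so far, a number 24 percentage points lower from compound 2 to compound 3 (beyond the scatter), put ethylamino in place of piperidin-1-yl on the carbonyl carbon. Compound 4 `N#C[C@@H]1CCCN1C(=O)[C@@H]1C[C@H](C(=O)N2CCC2)CN1` reverses the sense of that change: azetidin-1-yl in place of ethylamino on a carbonyl carbon. Among the measured compounds shown here, as in compound 2, the carbonyl again carries a ring nitrogen rather than an ethylamino group, though the ring here is four-membered and no measured pair has tested a ring of that size.

Because a number 24 percentage points lower from compound 2 to compound 3 (beyond the scatter) marks a fall on moving from the ring amide to the ethylamide, an increase of similar size is expected on going back to a ring amide, tempered by the untested ring size. Compound 4 is therefore estimated at 78%, within 64% to 90%, the expected step being a number 18 percentage points higher from compound 3 to compound 4 (beyond the scatter).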

Compound 4, a percentage reported as inhibition, in the whole organism at one dose (the size of the read-out at that dose, not a potency): 77%
Beside the measured number, compound 4's estimate is 1 percentage points above it; measured number inside the range.
By their numbers in this assay, from the lowest: compound 3; then compounds 4, 2 and 1 (each within the scatter of the next, the first and the last beyond it).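

In this assay, the rise in this step, a number 17 percentage points higher from compound 3 to compound 4 (beyond the scatter), shows that the fall seen earlier at this carbonyl carbon is reversed by a ring amide other than piperidin-1-yl, so the effect is not confined to that one ring. The comparison between the two ring amides, a number 7 percentage points lower from compound 2 to compound 4 (within the scatter), shows that this read-out does not separate the four-membered ring from piperidin-1-yl at this position. No measurement available here gives a reason for the difference between these ring amides and ethylamino.

Putting azetidin-1-yl in place of ethylamino both adds a ring and removes the hydrogen-bond donor counted on ethylamino, and these compounds cannot separate those two changes. Dimethylamino on the same carbonyl carbon, an open-chain group with no amide hydrogen, would pull them apart.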